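The compounds below may be only part of what the source reports. "The series", "measured", "known", "first", "only" and "open" are said of these compounds alone.

Of the compounds shown here, three of one shared core have been measured in an assay on isolated protein for agonist activity at Bile acid receptor (Homo sapiens), read by AlphaScreen, with a stated time of 30 min; a higher number here means a larger maximal response, a lower number a smaller maximal response. Compound 1 `CCc1ccccc1-n1nc(C)c2c1NC(=O)[C@H](C)S[C@@H]2c1ccc(Oc2ccccc2)cc1` gives 190%. Compound 2 `COc1cccc(-c2ccc([C@H]3S[C@@H](C)C(=O)Nc4c3c(C)nn4-c3ccccc3C)cc2)c1` gives 41%, and compound 3 `Cc1ccccc1-n1nc(C)c2c1NC(=O)[C@H](C)S[C@@H]2c1ccc(-c2cc3ccccc3o2)cc1` gives 17%. Compound 3 thus stands lowest of the three: the nearest number is that of compound 2, reached by the step of a number 24 percentage points lower from compound 2 to compound 3 (beyond the scatter), while compound 1 lies far above it.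

Compound 4 `COc1ccccc1-c1ccc([C@H]2S[C@@H](C)C(=O)Nc3c2c(C)nn3-c2ccccc2C)cc1` is the next compound, differing from compound 3 in one place: 2-methoxyphenyl in place of 1-benzofuran-2-yl on an aromatic carbon

Among the measured compounds shown here, only one measured step bears on this change, namely the one in which 1-benzofuran-2-yl replaced 3-methoxyphenyl at the same position, which was a number 24 percentage points lower from compound 2 to compound 3 (beyond the scatter), a modest fall. The present change runs in the opposite direction, from 1-benzofuran-2-yl to a methoxyphenyl again, so a rise of similar size is expected in this assay, bringing compound 4 back toward the level of compound 2 rather than toward that of compound 1. From the compounds shown here alone, the difference between 2-methoxyphenyl and 3-methoxyphenyl remains untested here, so the expectation is uncertain. For compound 4 the expected step is a number 23 percentage points higher from compound 3 to compound 4 (beyond the scatter). Compound 4 is therefore estimated at 40%, with a range from 18% to 80%.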

Compound 4, largest response reached (reported as efficacy), in percent of the reference or control that the assay uses: 50%
The estimate for compound 4 lay 10 percentage points below the measured number, and the stated range covers the measured number.
By their numbers in this assay, from the lowest: compound 3; then compounds 2 and 4 (each within the scatter of the next); then compound 1.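

In this assay, among the compounds shown here, replacing 1-benzofuran-2-yl with 2-methoxyphenyl on this aromatic carbon, para to a large group, gives a number 33 percentage points higher from compound 3 to compound 4 (beyond the scatter), so a methoxyphenyl group other than the one in compound 2 also reverses the earlier fall. Changing 3-methoxyphenyl to 2-methoxyphenyl gives a number 9 percentage points higher from compound 2 to compound 4 (within the scatter), so these two groups cannot be told apart here, and among the three groups compared at this position only 1-benzofuran-2-yl stands apart. No measurement at hand explains the difference between the benzofuran and the methoxyphenyl groups.

From the compounds shown here alone, it remains open whether the methoxy group matters at all, or whether an unsubstituted phenyl, a pyridine ring or a phenyl carrying a hydroxyl or an aminomethyl group would give a similar response at this position. Going by these compounds, how compound 1 reaches 190% also stays open, as it differs from the other compounds in more than one place and no single change can be read from it.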